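Adding fluoro to the hydroxy compound

The compounds below may be only part of what the source reports. "The series", "measured", "known", "first", "only" and "open" are said of these compounds alone.

Values so far in a functional assay on HOP-62 cells (Homo sapiens) for inhibition, read by sulforhodamine B assay; a higher number here means a weaker inhibitor of growth, a lower number a stronger inhibitor of growth
compound 1 `c1ccc(-c2ccc(-c3ccc(-c4nc5ccccc5[nH]4)cc3)cc2)cc1` gives 100000 nM
compound 2 `Fc1ccc(-c2ccc(-c3ccc(-c4nc5ccccc5[nH]4)cc3)cc2)cc1` gives 39300 nM
compound 3 `Oc1cccc2[nH]c(-c3ccc(-c4ccc(-c5ccccc5)cc4)cc3)nc12` gives 9040 nM

Compound 3 has the lowest number of the three, and both gaps to the other compounds lie beyond the scatter. The next step leads to compound 4 `Oc1cccc2[nH]c(-c3ccc(-c4ccc(-c5ccc(F)cc5)cc4)cc3)nc12` and puts fluoro in place of hydrogen on an aromatic carbon so that phenyl becomes 4-fluorophenyl, para to a large group.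

For the measured compounds named here, two measured steps bear on this. The same replacement has been measured once, without the hydroxy group, as a 2.5-fold lower number from compound 1 to compound 2 (0.41 log units; beyond the scatter) and this is a modest step beyond the scatter. The hydroxy replacement gave an 11-fold lower number from compound 1 to compound 3 (1.04 log units; beyond the scatter) and this large step is what places compound 3 where it stands. Going by the values given here, no measured compound yet carries both groups, so the data do not show whether the two steps combine. A modest step towards a lower number is therefore expected in this assay with a wide margin that includes almost no change. The expected step is a 2.3-fold lower number from compound 3 to compound 4 (0.35 log units; beyond the scatter) and rests on that single precedent. The estimated value for compound 4 is 4000 nM in this assay (estimated range 1500 nM to 11000 nM).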

Compound 4, concentration for 50% growth inhibition: 8310 nM
Compound 4: middle estimate off by 2.1-fold (0.32 log units), on the low side; low and high end bracket the measured number.
By their numbers in this assay, from the lowest: compounds 4 and 3 (each within the scatter of the next); then compound 2; then compound 1.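

In this assay, phenyl to 4-fluorophenyl para to a large group, now read with the hydroxy group present, gives a 1.1-fold lower number from compound 3 to compound 4 (0.04 log units; within the scatter), so the fluoro step seen without the hydroxy group does not rise above the scatter here, although the two readings of this change do not differ beyond the scatter: the same change on two cores in this assay, a 2.5-fold lower number (0.41 log units; beyond the scatter) from compound 1 to compound 2 and a 1.1-fold lower number (0.04 log units; within the scatter) from compound 3 to compound 4, 2.3-fold (0.37 log units) apart, within the scatter of two such steps

The hydroxy replacement now has a second reading on the fluoro-bearing core, a 4.7-fold lower number from compound 2 to compound 4 (0.67 log units; beyond the scatter), which shows that its step beyond the scatter is not confined to the core of compound 1, and its two readings also agree within the scatter: the same change on two cores in this assay, an 11-fold lower number (1.04 log units; beyond the scatter) from compound 1 to compound 3 and a 4.7-fold lower number (0.67 log units; beyond the scatter) from compound 2 to compound 4, 2.3-fold (0.37 log units) apart, within the scatter of two such steps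

With both gaps inside the scatter, the two groups can be read as neither clearly additive nor clearly interfering, and a single pair of cores cannot separate those cases.

Still open, on these data alone, is whether a group other than fluoro at this place, such as chloro, methoxy or an amine, would produce a step beyond the scatter on the hydroxy core. As far as these compounds go, it is also open whether the hydroxy group itself could be exchanged for methoxy or a carboxylic acid and keep its step in this assay.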